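Trading a cyclopropyl for an ethyl on the amide

The compounds below may be only part of what the source reports. "The series", "measured", "known", "first", "only" and "open" are said of these compounds alone.

Measured so far:
Compound 1 `CCn1c(-c2ccc(C(F)(F)F)nc2)nc2c(O[C@H]3CCN(C(=O)[C@H]4C[C@@H](OC)C4)C3)ncnc21` gives 35 10^-6 cm/s
Compound 2 `CCn1c(-c2cnc(C)nc2)nc2c(O[C@H]3CCN(C(=O)C4CC4)C3)ncnc21` gives 28 10^-6 cm/s

In an ADME assay on LLC-PK1 cells (Sus scrofa) for permeability (a lower number here means that the compound crosses the layer more slowly, a higher number that the compound crosses the layer faster), compound 2 holds the lower of the two numbers, and compound 1 sits close to it, within the usual scatter. Compound 3 `CCC(=O)N1CC[C@H](Oc2ncnc3c2nc(-c2cnc(C)nc2)n3CC)C1` differs from compound 2 by ethyl in place of cyclopropyl on a carbonyl carbon. Among the compounds with values here, no measured pair shows this change, so nothing beyond the scatter is expected in this assay, with a small drop as likely as none. Compound 3 is expected to give 26 10^-6 cm/s, between 15 10^-6 cm/s and 45 10^-6 cm/s, an estimated step of a 1.1-fold lower number from compound 2 to compound 3 (0.03 log units; within the scatter).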

Compound 3, apparent permeability: 21 10^-6 cm/s
Compound 3: the middle estimate sits 1.2-fold (0.09 log units) above what was measured, and the stated range covers the measured number.
By their numbers in this assay, from the lowest: compounds 3, 2 and 1 (each within the scatter of the next).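

In this assay, within the data shown here, this is the first comparison that changes only the group on the amide carbonyl, and ethyl in place of cyclopropyl gives a 1.3-fold lower number from compound 2 to compound 3 (0.12 log units; within the scatter). Here, removing the three-membered ring and one carbon leaves the number within the usual scatter. No measurement available here accounts for the size of this step. Still open, on these data alone, is whether a longer chain, or a group carrying an amine or a carboxylic acid, on this carbonyl carbon would also stay this close to compound 2.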